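Solubility notes on compounds 1 to 3

The compounds below may be only part of what the source reports. "The series", "measured", "known", "first", "only" and "open" are said of these compounds alone.

Compound 1 `CC(C)(C)c1ccc(Oc2ccc3c(NCCCNCc4ccco4)ccnc3c2)cc1`: 14500 nM
Compound 2 `CN(C)c1cccc(Oc2ccc3c(NCCCNCc4ccco4)ccnc3c2)c1`: 14500 nM
Compound 3 `c1coc(CNCCCNc2ccnc3cc(C4CCCCC4)ccc23)c1`: not yet measured

In a physicochemical assay for solubility, with a stated time of 18 h, at pH 7.4 (on this read-out lower numbers stand for lower solubility and higher numbers for higher solubility), compound 2 gives 14500 nM, level with compound 1 at 14500 nM. Going by the values given here, the only measured step, no change at the digits printed from compound 1 to compound 2 (within the scatter), swapped one six-membered aromatic ring of carbon only for another on the oxygen and stayed within the scatter. Compound 3 departs further: cyclohexyl in place of 3-(dimethylamino)phenoxy on an aromatic carbon. Among the compounds with values here, no measured step removes the oxygen link or a whole aromatic ring, so that step offers only weak guidance. The step is expected to be a 1.2-fold lower number from compound 2 to compound 3 (0.08 log units; within the scatter). Compound 3 is expected at 12000 nM, with a range of 4000 nM to 40000 nM.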

Compound 3, solubility: 4200 nM
Compound 3: middle estimate off by 2.9-fold (0.46 log units), on the high side, and the stated range covers the measured number.
By their numbers in this assay, from the lowest: compound 3; then compounds 1 and 2 (each within the scatter of the next).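

In this assay, cyclohexyl in place of 3-(dimethylamino)phenoxy on this aromatic carbon gives a 3.5-fold lower number from compound 2 to compound 3 (0.54 log units; beyond the scatter), whereas the earlier change on the oxygen gave no change at the digits printed from compound 1 to compound 2 (within the scatter). Replacing the whole group therefore moves the number, but the oxygen link, the aromatic ring and the dimethylamino group all leave together, and the compounds shown do not separate them. No measurement at hand bears on the cause of this step. From the compounds shown here alone, whether cyclohexyloxy or morpholine at this carbon would read nearer compound 2 or compound 3 remains open.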